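A few compounds are considered here, and "the series" means these few. Any claim that something is new, unique, unknown or untested is made for them only; others in the source may bear on it.

Measured in a functional assay on HeLa cells (Homo sapiens) for cytotoxicity, read by MTT assay, with a stated time of 48 h; a higher number here means a weaker inhibitor, a lower number a stronger inhibitor:
compound 1 `COc1cc(-c2ocnc2-c2cc(Br)c(OC)c(OC)c2)ccc1SC`: 440 nM
compound 2 `COc1ccc(-c2ocnc2-c2cc(Br)c(OC)c(OC)c2)cc1SC`: 630 nM

Only these two compounds have been measured so far. In this assay, compound 2 gives 630 nM, which lies within the usual scatter of compound 1 at 440 nM, so the two values cannot be told apart.

The next compound is compound 3 `COc1ccc(-c2ocnc2-c2cc(Br)c(OC)c(OC)c2)cc1OC`, which departs from compound 2 at a single place. It carries methoxy in place of methylsulfanyl on an aromatic carbon, ortho to a methoxy group and meta to a large group (methoxy in place of methylsulfanyl on an aromatic carbon). Among the compounds with values here, no measured pair differs at only one place, so the data offer no direct precedent for the size of this exchange. The expectation in this assay therefore rests on the value of compound 2 at 630 nM, with a wide margin on either side, and no direction is favoured. The expected change is a 1.1-fold lower number from compound 2 to compound 3 (0.06 log units; within the scatter), which would not go beyond the scatter. The estimated value for compound 3 is 550 nM, within an expected range of 130 nM to 2400 nM.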

Compound 3, half-maximal inhibitory concentration: 70 nM
Compound 3: the middle estimate sits 7.9-fold (0.90 log units) above what was measured; measured number below the stated range.
By their numbers in this assay, from the lowest: compound 3; then compounds 1 and 2 (each within the scatter of the next).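

In this assay the exchange of methylsulfanyl for methoxy on the aromatic carbon ortho to a methoxy group produces the first difference in this series that lies beyond the scatter (a 9.0-fold lower number from compound 2 to compound 3 (0.95 log units; beyond the scatter)). The same exchange starting from compound 1, where the methylsulfanyl group stands elsewhere on the same ring, also gives a lower number (a 6.3-fold lower number from compound 1 to compound 3 (0.80 log units; beyond the scatter)), so compound 1 and compound 2, which could not be told apart, both fall behind compound 3 and methylsulfanyl gives the higher number at either place. Nothing available here accounts for a step of this size from exchanging sulfur for oxygen.

The compounds shown leave open how a hydroxyl group, an ethoxy group or an amine on this carbon would read in this assay, so it cannot yet be said whether methoxy is the particular requirement or methylsulfanyl alone is the poorer group. They also leave open whether the step would persist if the bromine of the shared core were replaced by chlorine or a methyl group.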